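Nitrofuran chalcone series: cytotoxicity on Vero cells

This account rests on a few compounds, and the source may have more. Where it says the series, first, only, none or still open, it means among the compounds named here.

Compound 1 `COc1ccc(C(=O)/C=C/c2ccc([N+](=O)[O-])o2)cc1`: 571000 nM
Compound 2 `O=C(/C=C/c1ccc([N+](=O)[O-])o1)c1ccc(OCc2ccccc2)cc1`: 515000 nM
Compound 3 `O=C(/C=C/c1ccc([N+](=O)[O-])o1)c1ccc(OCc2ccc(F)cc2)cc1`: 430000 nM

Of the compounds shown here, three sharing one core have been measured in a toxicity assay on Vero cells (Chlorocebus sabaeus) for cytotoxicity; a higher number here means that more compound is tolerated, a lower number that less compound is tolerated. Compound 3 gives the lowest of the three numbers, but the step of a 1.2-fold lower number from compound 2 to compound 3 (0.08 log units; within the scatter) and the step of a 1.3-fold lower number from compound 1 to compound 3 (0.12 log units; within the scatter) both lie within the scatter, so the three compounds cannot be told apart on these values. Compound 4 `COc1ccc(COc2ccc(C(=O)/C=C/c3ccc([N+](=O)[O-])o3)cc2)cc1` is not yet measured in this assay. It differs from compound 3 by one change, (methoxy in place of fluoro on an aromatic carbon). Within the data shown here, no measured step carries this exact exchange; the nearest comparisons are the step from compound 1 to compound 2 a 1.1-fold lower number from compound 1 to compound 2 (0.04 log units; within the scatter) and the step from compound 1 to compound 3 a 1.3-fold lower number from compound 1 to compound 3 (0.12 log units; within the scatter), both within the scatter, which show that what stands on the benzyl ring has so far left the numbers unmoved. Compound 4 is therefore expected to show a 1.1-fold higher number from compound 3 to compound 4 (0.04 log units; within the scatter), a step not beyond the scatter. The estimate for compound 4 in this assay is 470000 nM, ranging from 260000 nM to 850000 nM.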

Compound 4, half-maximal cytotoxic concentration: 311000 nM
Compound 4: the middle estimate sits 1.5-fold (0.18 log units) above what was measured; measured number inside the range.
By their numbers in this assay, from the lowest: compounds 4, 3, 2 and 1 (each within the scatter of the next).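

Methoxy on the aromatic carbon where compound 3 carries fluoro gives a 1.4-fold lower number from compound 3 to compound 4 (0.14 log units; within the scatter) in this assay and, set against hydrogen at that place, a 1.7-fold lower number from compound 2 to compound 4 (0.22 log units; within the scatter) and so hydrogen, fluoro and methoxy at this position all stay within the scatter of one another. The whole 4-methoxyphenyl in place of hydrogen on the saturated chain carbon gives a 1.8-fold lower number from compound 1 to compound 4 (0.26 log units; within the scatter) and also remains within the scatter, so the flat reading now extends to a group that brings a hydrogen-bond acceptor. Nothing measured alongside these values speaks to a cause.

Going by these compounds, whether an amine or a carboxylic acid at this position, or a longer chain in place of the methoxy, would carry the number beyond the scatter stays open. All four compounds also keep the shared core, so they leave open how far the numbers in this assay depend on it.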